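Aryl ether variation on the diamino core: compound 4

The source may hold more compounds than are shown below. What is called first, only, known or untested is meant among the compounds shown, and "the series" means these compounds.

Working notes on the series. Compound 1 `Nc1cc(N)c2nc(-c3ccccc3)c(Oc3ccc(Cl)c(Cl)c3)nc2c1` is the weakest growth inhibitor of the three measured compounds: in a functional assay on OVCAR-8 cells (Homo sapiens) for inhibition, read by sulforhodamine B assay, with a stated time of 48 h (a lower number here means a stronger inhibitor of growth, a higher number a weaker inhibitor of growth), compound 1 gives 28200 nM. Compound 3 `CCOC(=O)[C@H](CCC(=O)O)NC(=O)c1ccc(Sc2nc3cc(N)cc(N)c3nc2-c2ccccc2)cc1` gives 12000 nM in this assay, and compound 2 `Nc1cc(N)c2nc(-c3ccccc3)c(NCc3ccc(Cl)c(Cl)c3)nc2c1` gives 3390 nM; both numbers lie beyond the scatter below the number for compound 1. Compound 4 `Nc1cc(N)c2nc(-c3ccccc3)c(Oc3ccc(F)cc3)nc2c1` has not been measured and differs from compound 1 in one place: 4-fluorophenyl in place of 3,4-dichlorophenyl on an oxygen on an aromatic ring. Read one bond further out, the change is 3,4-dichlorophenoxy to 4-fluorophenoxy, and no measured pair in the series shows this change. The step of a 1.2-fold higher number from compound 1 to compound 4 (0.09 log units; within the scatter) is expected to be small, either within the scatter or a modest weakening. For compound 4 the estimate in this assay is 35000 nM, with an expected range from 10000 nM to 100000 nM.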

Compound 4, concentration for 50% growth inhibition: 22400 nM
The estimate for compound 4 lay 1.6-fold (0.19 log units) above the measured number; the range from low to high includes it.
By their numbers in this assay, from the lowest: compound 2; then compounds 3, 4 and 1 (each within the scatter of the next, the first and the last beyond it).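

In this assay, 4-fluorophenyl in place of 3,4-dichlorophenyl on an oxygen on an aromatic ring gives a step within the scatter (a 1.3-fold lower number from compound 1 to compound 4 (0.10 log units; within the scatter)). Among these compounds, this is the first one-place comparison, and at this position it separates the two aryl groups by no readable margin. Nothing measured here offers a reason for this result.

Still open, from the compounds shown here alone, is how an unsubstituted phenyl, or a phenyl carrying an amine or a carboxylic acid, would read on this oxygen. Going by these compounds, a benzyl group in the same place is equally open.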